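Aryl piperazine variation on a shared oxindole-type series

The source may report more compounds than this note shows. Statements on the series, on what has been measured and on what is new or still open speak of the compounds shown alone.

Measured compounds:
compound 1 `CCC1(CCCCN2CCN(c3cccc(Cl)c3)CC2)C(=O)Nc2cc(F)ccc21` — 0.67 nM
compound 2 `CCC1(CCCCN2CCN(c3cccc(OC)c3)CC2)C(=O)Nc2ccccc21` — 2.55 nM

In an assay on CHO cells for displacement of a labelled ligand from 5-hydroxytryptamine receptor 7 (Homo sapiens) (on this read-out lower numbers stand for stronger inhibition and higher numbers for weaker inhibition), compound 1 gives 0.67 nM, while compound 2 gives 2.55 nM. Compound 2 thus holds the highest of the two numbers, with compound 1 its nearest neighbour at a lower number, a gap beyond the scatter. Compounds 1 and 2 differ in more than one place, so no single step can be read from that pair.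

Compound 3 `CCC1(CCCCN2CCN(c3ccccc3Cl)CC2)C(=O)Nc2ccccc21` is not yet measured. It derives from compound 2 by one change: 2-chlorophenyl in place of 3-methoxyphenyl on an amine nitrogen in a ring. Among the measured compounds shown here, no measured pair isolates this change, so there is no step to lean on. The step from compound 2 to compound 3 is expected to be small, toward a higher number, and possibly within the scatter: a 2.0-fold higher number from compound 2 to compound 3 (0.29 log units; within the scatter). Compound 3 is expected to give about 5 nM in this assay, with a range from 1.5 nM to 20 nM.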

Compound 3, inhibition constant: 5.11 nM
The estimate for compound 3 lay 1.0-fold (0.01 log units) below the measured number, within the range that was stated.
By their numbers in this assay, from the lowest: compound 1; then compounds 2 and 3 (each within the scatter of the next).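

In this assay, the series now has its first step that can be read at a single place: 2-chlorophenyl in place of 3-methoxyphenyl on the ring amine nitrogen gives a 2.0-fold higher number from compound 2 to compound 3 (0.30 log units; within the scatter). This position therefore accepts this exchange of one substituted phenyl for another, even though the entering group carries no hydrogen-bond acceptor and the leaving group carries one. The step swaps the substituent and its place on the phenyl together, so the two cannot be separated, and no measurement here offers an explanation for the result.

As far as these compounds go, whether compound 1 owes its lower number to its aryl group or to the fluorine on its core remains open, as it differs from compound 2 and compound 3 in more than one place. Also open, from the compounds shown here alone, is how unsubstituted phenyl or 2-methoxyphenyl on the same nitrogen would compare.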